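The source may report more compounds than this note shows. Statements on the series, on what has been measured and on what is new or still open speak of the compounds shown alone.

Measured compounds:
Compound 1, `COc1cc(OC)c(OC)cc1/C=C/C(=O)c1c(O)cc(C)oc1=O`: in an ADME assay on HEK293 cells (Homo sapiens) for cytotoxicity, read by MTT assay (on this read-out lower numbers stand for stronger inhibition and higher numbers for weaker inhibition), compound 1 gives 100000 nM.
Compound 2, `Cc1cc(O)c(C(=O)/C=C/c2cccc(Br)c2)c(=O)o1`: in this assay compound 2 gives 100000 nM.

Compound 2 stands level with compound 1 at the digits shown; the two values lie within the scatter, so no order can be read between them.

Compound 3, `Cc1cc(O)c(C(=O)/C=C/c2cccc(O)c2)c(=O)o1`, is not yet measured in this assay. It differs from compound 2 by hydroxy in place of bromo on an aromatic carbon. Within the data shown here, no step between measured compounds informs this change, so the expectation rests on the two values shown, both at the same level. The step from compound 2 to compound 3 is expected to be none beyond the scatter, no change at the digits printed from compound 2 to compound 3 (within the scatter). Compound 3 is therefore estimated at 100000 nM, with a range from 50000 nM to 200000 nM.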

Compound 3, half-maximal inhibitory concentration: > 100000 nM
Compound 3: a limit, no number; the forecaster's own chance of this, stated with the estimate: 25%; the middle value sits exactly at the limit.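

In this assay hydroxy in place of bromo, on an aromatic carbon meta to a large group, gives a number no lower from compound 2 to compound 3 (the limit leaves the size open) here. Compound 3 reads > 100000 nM as a limit, not a number. This position thus holds either group without a lower number appearing on this read-out, and the size of the change stays unreadable because of the limit: the limit of > 100000 nM in this assay, at which 1 of the 3 values shown sits.

On these data alone, whether an amine or a carboxylic acid on this carbon would give a lower number stays open.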